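A few compounds are considered here, and "the series" means these few. Any claim that something is new, unique, unknown or untested is made for them only; others in the source may bear on it.

Compound 2 `O=c1ccc(-n2cnc3ccccc32)nn1CCCCCN1CCN(c2ccccc2Cl)CC1` gives 4.5 nM in an assay on cell membranes from brain for binding affinity to Adrenergic receptor alpha-1 (Rattus norvegicus), read by radioligand binding (on this read-out higher numbers stand for weaker inhibition and lower numbers for stronger inhibition), which places it second highest among the three compounds measured. Among the compounds with values here, its nearest neighbour is compound 1 `COc1ccccc1N1CCN(CCCCCn2nc(-n3cnc4ccccc43)ccc2=O)CC1`, which gives 3.1 nM in this assay; the only change between them is a 1.5-fold higher number from compound 1 to compound 2 (0.16 log units; within the scatter). Compound 3 `COc1ccccc1N1CCN(CCCCn2nc(-n3ccnc3)ccc2=O)CC1` gives 47.5 nM in this assay, a number beyond the scatter from both of the others.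

Compound 4 `O=c1ccc(-n2ccnc2)nn1CCCCCN1CCN(c2ccccc2Cl)CC1` is the next compound, not yet measured. Compared with compound 2 the change is 1H-imidazol-1-yl in place of 1H-benzimidazol-1-yl on an aromatic carbon. Within the data shown here, no measured step follows this replacement on its own. Compound 3, however, carries the same imidazolyl group in place of the benzimidazolyl group of compound 1, together with a shorter chain, and its number is far higher than that of compound 1. The expected step from compound 2 to compound 4 in this assay is therefore a rise to a weaker inhibition, and a sizeable one. Compound 4 is estimated to give 35 nM, within a range of 10 nM to 120 nM. The step this estimate implies, a 7.8-fold higher number from compound 2 to compound 4 (0.89 log units; beyond the scatter), is expected rather than measured.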

Compound 4, inhibition constant: 23.3 nM
The estimate for compound 4 lay 1.5-fold (0.18 log units) above the measured number, and the stated range covers the measured number.
By their numbers in this assay, from the lowest: compounds 1 and 2 (each within the scatter of the next); then compound 4; then compound 3.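

Within the data shown here, the step of a 5.2-fold higher number from compound 2 to compound 4 (0.71 log units; beyond the scatter) in this assay gives the first reading of this replacement on its own. The chain and the rest of the molecule stay the same; in compound 3, the imidazolyl group came together with a shorter chain. On this aromatic carbon, replacing 1H-benzimidazol-1-yl with 1H-imidazol-1-yl removes the six-membered aromatic ring of carbon only while the counts of hydrogen-bond donors and acceptors stay the same, and inhibition is weaker by more than the scatter. Nothing available here explains why this change weakens inhibition.

Still open, from the compounds shown here alone, is how a phenyl group or a 1H-indol-1-yl group would compare at this position. Going by these compounds, the step is also known only with the chloro group and the five-carbon chain, so its size with the methoxy group or a longer chain remains unknown.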